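A few compounds are considered here, and "the series" means these few. Any claim that something is new, unique, unknown or untested is made for them only; others in the source may bear on it.

In a functional assay on MDA-MB-231 cells (Homo sapiens) for antiproliferative activity, read by MTT assay, with a stated time of 48 h (on this read-out higher numbers stand for weaker inhibition and lower numbers for stronger inhibition), compound 1 `CCOC(=O)CN(Cc1ccccc1)c1nc(NCc2ccccc2)ncc1[N+](=O)[O-]` gives 82400 nM and compound 2 `CCOC(=O)CN(Cc1ccccc1)c1nc(NCc2cccc(OC)c2)ncc1[N+](=O)[O-]` gives 80700 nM. The step of a 1.0-fold lower number from compound 1 to compound 2 (0.01 log units; within the scatter), a methoxy in place of hydrogen on an aromatic carbon, therefore stays within the scatter. Compound 3 `CCOC(=O)CN(Cc1ccccc1)c1nc(Nc2ccccc2)ncc1[N+](=O)[O-]` is reported only as a limit of this assay, > 100000 nM, one of the values that sit at the limit of > 100000 nM in this assay, at which 1 of the 3 values shown sits. Against compound 1 this amounts to an at least 1.2-fold higher number from compound 1 to compound 3 (0.08 log units; that floor lies within the scatter), and against compound 2 to an at least 1.2-fold higher number from compound 2 to compound 3 (0.09 log units; that floor lies within the scatter); both floors lie within the scatter, so compound 3 cannot be ranked against either.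

Compound 4 `CCOC(=O)CN(Cc1ccccc1)c1nc(Nc2cc(OC)c(OC)c(OC)c2)ncc1[N+](=O)[O-]` differs from compound 3 by 3,4,5-trimethoxyphenyl in place of phenyl on a nitrogen on an aromatic ring, that is, 3,4,5-trimethoxyphenyl in place of phenyl on the nitrogen whose other neighbour is an aromatic carbon. Among the compounds with values here, the only measured step that resembles it, the methoxy added on the benzyl of compound 1 to give compound 2, was a 1.0-fold lower number from compound 1 to compound 2 (0.01 log units; within the scatter) and changed nothing beyond the scatter. The author thus expects no step beyond the scatter in this assay from the change, while noting that the starting point, compound 3, is itself only a limit. Compound 4 is accordingly estimated at 110000 nM, between 45000 nM and 260000 nM, which would be a step that the limit leaves unreadable from compound 3 to compound 4 from compound 3 to compound 4.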

Compound 4, half-maximal inhibitory concentration: 40400 nM
The estimate for compound 4 lay 2.7-fold (0.44 log units) above the measured number; measured number below the stated range.
By their numbers in this assay, from the lowest: compounds 4, 2 and 1 (each within the scatter of the next, the first and the last beyond it). At a limit, above all of these: compound 3.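

At this position, on the nitrogen on an aromatic ring, this assay now gives a change that can be read beyond the scatter: the 3,4,5-trimethoxyphenyl group in place of phenyl gives an at least 2.4-fold lower number from compound 3 to compound 4 (0.39 log units; beyond the scatter) as a floor, whereas each step among compounds 1, 2 and 3 stayed within the scatter or could not be ranked. Compound 3 is reported only as a limit: the limit of > 100000 nM in this assay, at which 1 of the 4 values shown sits. Against the benzyl group of compound 1, the same 3,4,5-trimethoxyphenyl group gives a 2.0-fold lower number from compound 1 to compound 4 (0.31 log units; beyond the scatter) and so a modest step beyond the scatter, but against the 3-methoxybenzyl group of compound 2 it gives a 2.0-fold lower number from compound 2 to compound 4 (0.30 log units; within the scatter) and so does not separate the two compounds.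

The compounds shown leave open whether one methoxy on the phenyl would match the three methoxy groups of compound 4, and whether a chlorine or a dimethylamino group there would do the same. They also leave open whether the step would hold with the ethyl ester of the shared core replaced by a carboxylic acid or an amide.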